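Bromo to chloro on the shared core: compound 4 outlook

The source may hold more compounds than are shown below. What is called first, only, known or untested is meant among the compounds shown, and "the series" means these compounds.

Measured compounds in a functional assay on BEL-7404 cells for cytotoxicity against BEL-7404 tumor cell line (Homo sapiens), read by MTT assay, with a stated time of 48 h; a lower number here means a stronger inhibitor, a higher number a weaker inhibitor:
Compound 1 `O=c1[nH]c2ccccc2cc1-c1nc2cc(Br)ccc2[nH]1` gives 14500 nM.
Compound 2 `Cc1cc2nc(-c3cc4ccccc4[nH]c3=O)[nH]c2cc1C` reaches only a limit of the assay, > 100000 nM.
Compound 3 `Cc1ccc2[nH]c(=O)c(-c3nc4cc(Br)ccc4[nH]3)cc2c1` likewise reaches only a limit, > 100000 nM.

Within the data shown here, compound 1 holds the only number in this assay; the remaining two values sit at a limit (the limit of > 100000 nM in this assay, at which 2 of the 3 values shown sit). Among the measured compounds shown here, the one step that can be sized, an at least 6.8-fold higher number from compound 1 to compound 3 (0.83 log units; beyond the scatter), comes from a methyl in place of hydrogen on an aromatic carbon.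

Compound 4 `O=c1[nH]c2ccccc2cc1-c1nc2cc(Cl)ccc2[nH]1` differs from compound 1 by chloro in place of bromo on an aromatic carbon. For the measured compounds named here, no measured step touches a halogen swap at this place, so the measured step gives no direct guide. A change within the scatter is expected for compound 4, estimated at 18000 nM with a range of 7000 nM to 50000 nM. The expected step is a 1.2-fold higher number from compound 1 to compound 4 (0.09 log units; within the scatter).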

Compound 4, half-maximal inhibitory concentration: 16500 nM
Compound 4: the middle estimate sits 1.1-fold (0.04 log units) above what was measured; low and high end bracket the measured number.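

Among these compounds, the swap of bromo for chloro on this aromatic carbon gives a 1.1-fold higher number from compound 1 to compound 4 (0.06 log units; within the scatter), the first step that stays within the scatter. At this position the two halogens cannot be told apart in this read-out, so compound 1 and compound 4 stand level on the shared core. Nothing measured bears on a cause for this.

Whether this position needs a halogen at all remains open, as no compound shown carries plain hydrogen there. Also open, as far as these compounds go, is how a larger or different group, such as methoxy or an amine, would read at this place.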